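Swapping Trifluoromethyl for Hydroxycyclopropyl on the Side Chain

This account rests on a few compounds, and the source may have more. Where it says the series, first, only, none or still open, it means among the compounds named here.

Compound 1 `O=c1n(Cc2nc3ccccc3n2CCCC(F)(F)F)c2cnccc2n1C1CC1`: 55700 nM
Compound 2 `N#CCCCn1c(Cn2c(=O)n(CC3CC3)c3ccncc32)nc2ccccc21`: 96500 nM
Compound 3 `O=c1n(Cc2nc3ccccc3n2CCCCO)c2cnccc2n1C1CCCC1`: > 246000 nM, a limit of the assay, not a number

All three were tested in an ADME assay on HEp-2 cells (Homo sapiens) for cytotoxicity; on this read-out higher numbers stand for lower toxicity in this test and lower numbers for higher toxicity in this test. Compound 1 has the lowest of the two numbers, with compound 2 sitting within the scatter of it, so the two cannot be told apart. Compound 3 reached only (the limit of > 246000 nM in this assay, at which 1 of the 3 values shown sits).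

Compound 4 `O=c1n(Cc2nc3ccccc3n2CCCC2(O)CC2)c2cnccc2n1C1CC1` has not yet been measured in this assay. It differs from compound 1 in one place: 1-hydroxycyclopropyl in place of trifluoromethyl on a saturated chain carbon, three bonds along the chain from an aromatic nitrogen. Going by the values given here, no measured pair shows this kind of change, so the size of the step is uncertain. For compound 4 a modestly higher number is expected, around 90000 nM, within 40000 nM to 250000 nM. The step of a 1.6-fold higher number from compound 1 to compound 4 (0.21 log units; within the scatter) is an estimate, not a measurement.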

Compound 4, half-maximal cytotoxic concentration: 131000 nM
Estimate against measurement, compound 4: 1.5-fold (0.16 log units) below, and the stated range covers the measured number.
By their numbers in this assay, from the lowest: compounds 1, 2 and 4 (each within the scatter of the next, the first and the last beyond it). At a limit, above all of these: compound 3.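

Going by these compounds alone, compound 1 and compound 4 form the first pair that differs in one place only, so a single change can now be read on its own. Putting 1-hydroxycyclopropyl in place of trifluoromethyl on a saturated chain carbon, three bonds along the chain from an aromatic nitrogen, gives a 2.4-fold higher number from compound 1 to compound 4 (0.37 log units; beyond the scatter) in this assay and so points to modestly lower toxicity in this test. Nothing measured here explains this step.

One pair cannot separate the part played by the hydroxy group from that of the three-membered ring. Going by these compounds, whether an amine or a carboxylic acid in the same place would move the number also remains open.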